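The source may hold more compounds than are shown below. What is called first, only, known or untested is meant among the compounds shown, and "the series" means these compounds.

Measured in an ADME assay on microsomes from liver (Rattus norvegicus) for metabolic stability, with a stated time of 10 min; a higher number here means that more of the compound is left, a lower number that less of the compound is left:
Compound 1 `Cc1cc(C)c(Nc2nc(Cl)cn([C@H](C)C3CC3)c2=O)c(C)n1`: 87%
Compound 2 `Cc1nc2c(cc1Nc1nc(Cl)cn([C@H](C)C3CC3)c1=O)COC2`: "not determined" (no result reported)
Compound 3 `CCOc1nc(C)c(Nc2nc(Cl)cn([C@H](C)C3CC3)c2=O)cc1C`: 93%

For the measured compounds named here, compound 3, at 93%, has only one number to be compared with: compound 1 at 87%. These two values lie within the usual scatter of each other, so they do not separate the two compounds. Compound 2 offers no comparison, since no result was reported for it.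

The next compound to be tested is compound 4 (`Cc1cc(Nc2nc(Cl)cn([C@H](C)C3CC3)c2=O)c(C)nc1N1CCCC1`), which has pyrrolidin-1-yl in place of ethoxy on an aromatic carbon, next to the ring nitrogen: pyrrolidin-1-yl in place of ethoxy on an aromatic carbon. Going by the values given here, no two measured compounds differ in just one place, so the data do not show how large such a change can be in this assay. The expectation is therefore a judgement, and it points to a moderate fall beyond the scatter, though little or no change remains possible. The expected step is a number 21 percentage points lower from compound 3 to compound 4 (beyond the scatter). For compound 4 the estimated value is 72%, with an expected range from 45% to 92%.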

Compound 4, percent of the compound remaining: 57%
Compound 4: middle estimate off by 15 percentage points, on the high side; the range from low to high includes it.
By their numbers in this assay, from the lowest: compound 4; then compounds 1 and 3 (each within the scatter of the next).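

In this assay, for the compounds shown here, replacing ethoxy with pyrrolidin-1-yl gives a number 36 percentage points lower from compound 3 to compound 4 (beyond the scatter), the first comparison in this set between compounds that differ in one place, and it shows that the group on this aromatic carbon, next to the ring nitrogen, can matter greatly. Neither group has a hydrogen-bond donor or a net charge, and each has 1 hydrogen-bond acceptor, so these counts do not separate them, whereas the entering group has 5 heavy atoms against 3 and a five-membered non-aromatic ring. Nothing measured here accounts for the size of this step.

The compounds shown leave open whether the fall goes with the ring or with the nitrogen attached to the aromatic carbon. An open-chain diethylamino group and a cyclopentyl ring at this place would tell these two apart.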